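A few compounds are considered here, and "the series" means these few. Any claim that something is new, unique, unknown or untested is made for them only; others in the source may bear on it.

Among the compounds with values here, compound 3, `CCCn1ncc2c(Nc3ccc(OC(F)(F)F)cc3)ncnc21`, is one of three compounds measured in an ADME assay on BaF3 cells (Mus musculus) for cytotoxicity (a higher number here means that more compound is needed for the effect, a lower number that less compound is needed), all built on the same core and differing only in the group attached to an aromatic nitrogen. In this assay compound 3 gives 6600 nM, the lowest of the two plain numbers. The nearest is compound 2, `FC(F)(F)Oc1ccc(Nc2ncnc3c2cnn3C2CCCCC2)cc1`, which in this assay gives 9300 nM. Compound 1, `Cc1nc(C)c(Cn2ncc3c(Nc4ccc(OC(F)(F)F)cc4)ncnc32)s1`, in this assay gives > 10000 nM, and that is a limit of the assay rather than a number (the limit of > 10000 nM in this assay, at which 1 of the 3 values shown sits).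

Compound 4, `CCn1ncc2c(Nc3ccc(OC(F)(F)F)cc3)ncnc21`, is to be measured next. It differs from compound 3 by hydrogen in place of methyl on a saturated chain carbon, two bonds along the chain from an aromatic nitrogen, so the chain on the aromatic nitrogen is shortened by one carbon. The measured steps that bear on this are the changes of the same group: a 1.4-fold lower number from compound 2 to compound 3 (0.15 log units; within the scatter) and an at least 1.5-fold lower number from compound 1 to compound 3 (0.18 log units; that floor lies within the scatter). Neither exceeds the scatter, even though they swap rather different groups, and the move from compound 3 to compound 4 is smaller than either. No step beyond the scatter is therefore expected in this assay. Compound 4 is estimated to give 7000 nM, within a range from 3500 nM to 14000 nM. The step expected from compound 3 to compound 4 is a 1.1-fold higher number from compound 3 to compound 4 (0.03 log units; within the scatter).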

Compound 4, half-maximal effective concentration: > 10000 nM
Compound 4: only a limit was reported; the forecaster's own chance of this, stated with the estimate: 25%; at least 1.4-fold (0.15 log units) between middle value and limit.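

In this assay the result for compound 4 is a limit of the assay and not a number, the same limit met by compound 1: the limit of > 10000 nM in this assay, at which 2 of the 4 values shown sit. Shortening the chain on the aromatic nitrogen from propyl to ethyl gives an at least 1.5-fold higher number from compound 3 to compound 4 (0.18 log units; that floor lies within the scatter), and putting ethyl in place of cyclohexyl gives an at least 1.0-fold higher number from compound 2 to compound 4 (0.03 log units; that floor lies within the scatter), so both steps are floors within the scatter and their true sizes stay unknown, while the step between compound 1 and compound 4 cannot be read at all. Within the data shown here, what is new is that the limit is no longer seen only with the (2,4-dimethyl-1,3-thiazol-5-yl)methyl group of compound 1: a change of one carbon at this position can be enough to carry a compound from a plain number to the limit.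

The compounds shown leave open whether compound 4 lies just past the limit or far past it, and so whether this one-carbon change is small or large. They also leave open what a methyl, a longer chain such as butyl, or a chain ending in an amine would give on this aromatic nitrogen.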